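Swapping the halophenyl group of compound 3

A few compounds are considered here, and "the series" means these few. Any claim that something is new, unique, unknown or untested is made for them only; others in the source may bear on it.

Measured so far in an ADME assay on Vero cells (Chlorocebus sabaeus) for cytotoxicity, read by MTT assay, with a stated time of 72 h; a lower number here means that less compound is tolerated, a higher number that more compound is tolerated:
compound 1 `COc1ccc(/C=C(\C)C(=O)/C=C/c2cccc(Br)c2)cc1`: 153000 nM
compound 2 `COc1ccc(/C=C(\C)C(=O)/C=C/c2ccc(F)cc2)cc1`: 68100 nM
compound 3 `CC/C(=C\c1ccc(Cl)cc1)C(=O)/C=C/c1ccccc1Br`: 24400 nM

Compound 3 at 24400 nM holds the lowest of the three numbers and lies beyond the usual scatter from both others, with compound 2 nearest and compound 1 furthest. Next comes compound 4 `CC/C(=C\c1ccc(Cl)cc1)C(=O)/C=C/c1ccc(Cl)cc1`, which has no measurement yet. The change is 4-chlorophenyl in place of 2-bromophenyl on a double-bonded chain carbon bound to a double-bonded chain carbon: 4-chlorophenyl in place of 2-bromophenyl, on a double-bonded chain carbon bound to a double-bonded chain carbon.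

For the measured compounds named here, one measured step bears on this change: a 2.2-fold lower number from compound 1 to compound 2 (0.35 log units; beyond the scatter). It is modest but beyond the scatter, and it also replaces a bromophenyl at this place, there a 3-bromophenyl, with a 4-substituted halophenyl. It is an imperfect guide, since the entering and leaving groups both differ here and compound 3 differs from compound 1 and compound 2 elsewhere too. A modest move to a lower number is therefore expected in this assay, with wide uncertainty, as the expectation rests on a single precedent. The expected step is a 1.5-fold lower number from compound 3 to compound 4 (0.18 log units; within the scatter) and no larger move is anticipated. Compound 4 is estimated at 16000 nM with 5500 nM to 48000 nM as the expected range.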

Compound 4, half-maximal cytotoxic concentration: 28300 nM
Compound 4: middle estimate off by 1.8-fold (0.25 log units), on the low side; measured number inside the range.
By their numbers in this assay, from the lowest: compounds 3 and 4 (each within the scatter of the next); then compound 2; then compound 1.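

In this assay replacing 2-bromophenyl with 4-chlorophenyl on a double-bonded chain carbon bound to a double-bonded chain carbon gives a 1.2-fold higher number from compound 3 to compound 4 (0.06 log units; within the scatter) and so does not separate these two groups, even though they carry different halogens at different numbered positions. The earlier exchange at this place (a 2.2-fold lower number from compound 1 to compound 2 (0.35 log units; beyond the scatter)) lay beyond the scatter, so the new pair shows that a change of halophenyl group here does not always register in this read-out, although the two pairs have different remainders and cannot be set directly against each other. Nothing measured here explains either outcome.

Still open, from the compounds shown here alone, is whether 2-bromophenyl and 4-chlorophenyl would also stay within the scatter of each other on the core of compound 1, and whether the halogen and its numbered position would each matter if changed separately. Also open, going by these compounds, is whether a phenyl group carrying an amine or a carboxylic acid at this place would move the number beyond the scatter from compound 3.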